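This account rests on a few compounds, and the source may have more. Where it says the series, first, only, none or still open, it means among the compounds named here.

In a functional assay for inhibition, with Cavia porcellus as the target (a higher number here means that more compound is needed for the effect, a lower number that less compound is needed), compound 2 `CC(C)COC(=O)CCCc1cc(CN2CCCC2)c(O)c(CN2CCCC2)c1` gives 2 ug/mL. Among the values shown, this is the only true number. Compound 1 `O=C(O)c1cc(CN2CCCC2)c(O)c(CN2CCCC2)c1` gives > 30 ug/mL in this assay, which is a limit of the assay rather than a measured number (the limit of > 30 ug/mL in this assay, at which 1 of the 2 values shown sits). Compound 3 `CC(C)COC(=O)CCc1cc(CN2CCCC2)c(O)c(CN2CCCC2)c1` has not yet been measured; it differs from compound 2 by isobutoxycarbonyl in place of (isobutoxycarbonyl)methyl on a saturated chain carbon, two bonds along the chain from an aromatic carbon. Among the measured compounds shown here, no measured step is available to compare with, so only a small shift is expected, estimated as a 1.5-fold higher number from compound 2 to compound 3 (0.18 log units; within the scatter), with compound 3 expected to give about 3 ug/mL, within a range from 1 ug/mL to 10 ug/mL.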

Compound 3, concentration for half-maximal effect: 14 ug/mL
Compound 3: the middle estimate sits 4.7-fold (0.67 log units) below what was measured; the measured number lies above the stated range.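

In this assay, isobutoxycarbonyl in place of (isobutoxycarbonyl)methyl on this saturated chain carbon gives a 7.0-fold higher number from compound 2 to compound 3 (0.85 log units; beyond the scatter), so even this small change in the chain makes a clear difference. Compound 1 stands at a limit of the assay, not at a true number: the limit of > 30 ug/mL in this assay, at which 1 of the 3 values shown sits. Having 2-(isobutoxycarbonyl)ethyl in place of carboxy on the aromatic carbon gives an at least 2.1-fold lower number from compound 1 to compound 3 (0.33 log units; beyond the scatter).

Going by these compounds, it remains open whether a longer chain would lower the number further than in compound 2. Also open, on these data alone, is whether a carboxylic acid or an amide at the chain end could take the place of the isobutyl ester.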